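Adding a nitro group to compound 3

The source may report more compounds than this note shows. Statements on the series, on what has been measured and on what is new or still open speak of the compounds shown alone.

Compounds measured so far in a functional assay on MCF7 cells (Homo sapiens) for cytotoxicity, read by MTT assay, with a stated time of 48 h; on this read-out lower numbers stand for stronger inhibition and higher numbers for weaker inhibition

- compound 1 `COc1ccc(-c2c[nH]c(=O)n2-c2cc(OC)c(OC)c(OC)c2)cc1[N+](=O)[O-]` with "not determined" (no result reported)
- compound 2 `COc1cc(-n2c(-c3ccccc3)cn(C(C)=O)c2=O)cc(OC)c1OC` with > 50000 nM as a limit
- compound 3 `COc1ccc(-c2cn(C(C)=O)c(=O)n2-c2cc(OC)c(OC)c(OC)c2)cc1` with > 50000 nM as a limit

Compound 3 has only a limit to show (> 50000 nM) and no exact number. Compound 2 also ends at a limit (> 50000 nM) and no exact number. So the picture is thin: the data show the limit of > 50000 nM in this assay, at which 2 of the 3 values shown sit, and little else.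

Compound 4 `COc1ccc(-c2cn(C(C)=O)c(=O)n2-c2cc(OC)c(OC)c(OC)c2)cc1[N+](=O)[O-]` differs from compound 3 in one place (nitro in place of hydrogen on an aromatic carbon), with nitro in place of hydrogen on an aromatic carbon. Among the compounds with values here, the only measured step is a step that the two limits leave unreadable from compound 2 to compound 3 and it concerns methoxy, not nitro, so it gives no size to carry over. Compound 1 carries a nitro group too, but it offers no guide ("not determined" (no result reported)).

With no measured size to lean on, the expectation stays close to the limit, and any change in this assay would most likely be towards stronger inhibition. The expected step, an estimate only, is an at least 1.2-fold lower number from compound 3 to compound 4 (0.09 log units; that floor lies within the scatter) and it may stay hidden behind the same limit. For compound 4 the estimated value is 40000 nM with an expected range from 5000 nM to 100000 nM as the likely span.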

Compound 4, half-maximal inhibitory concentration: > 50000 nM
Compound 4 gave a limit, no number; the forecaster's own chance of this, stated with the estimate: 65%; middle value at least 1.2-fold (0.09 log units) away from the limit.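

Compound 4, like compound 3, gives only a limit in this assay, so no step can be read between these two compounds. The compounds shown leave open what size of change, if any, nitro in place of hydrogen brings, as their results gather at one value: the limit of > 50000 nM in this assay, at which 3 of the 4 values shown sit.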